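The compounds below may be only part of what the source reports. "The series", "measured", "known", "first", "only" and "open" are said of these compounds alone.

Measured so far:
- compound 1, `O=C(COc1cccc2ccccc12)N/N=C/c1ccccc1O`: 20 ug/mL
- compound 2, `O=C(COc1cccc2ccccc12)N/N=C/c1cccc(Br)c1`: 100 ug/mL

In an ADME assay on HEL cells (Homo sapiens) for cytotoxicity (a higher number here means that more compound is tolerated, a lower number that less compound is tolerated), compound 2 gives the highest of the two numbers; the nearest is compound 1, and the step of a 5.0-fold higher number from compound 1 to compound 2 (0.70 log units; beyond the scatter) is the only one available. That step exchanges 2-hydroxyphenyl for 3-bromophenyl on the carbon with a double bond to nitrogen, and it is modest in size.

Compound 3, `COc1ccc(/C=N/NC(=O)COc2cccc3ccccc23)cc1`, is not yet measured. It differs from compound 2 as follows: 4-methoxyphenyl in place of 3-bromophenyl on a carbon with a double bond to nitrogen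

For the measured compounds named here, no measured step involves 4-methoxyphenyl, so the only step known, from compound 1 to compound 2, bears on this change merely by showing that the group on the carbon with a double bond to nitrogen can move the number in this assay by a modest amount. Without a closer comparison, no shift beyond the scatter is expected from compound 2 to compound 3 in this assay: the expected step is no change at the digits printed from compound 2 to compound 3 (within the scatter). The estimate for compound 3 in this assay is therefore 100 ug/mL, with a range of 40 ug/mL to 200 ug/mL.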

Compound 3, minimum cytotoxic concentration: 20 ug/mL
Estimate against measurement, compound 3: 5.0-fold (0.70 log units) above, and the stated range ends above it.
By their numbers in this assay, from the lowest: compounds 1 and 3 (each within the scatter of the next); then compound 2.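

In this assay, the group on the carbon with a double bond to nitrogen can move the number in either direction: the change to 4-methoxyphenyl gives a 5.0-fold lower number from compound 2 to compound 3 (0.70 log units; beyond the scatter), so the higher number of compound 2 does not carry over to this replacement of 3-bromophenyl. For the compounds shown here, the two oxygen-bearing groups do not separate, with no change at the digits printed from compound 1 to compound 3 (within the scatter), which leaves 3-bromophenyl as the only one of the three groups standing apart, and this three-compound pattern has no exception among compounds 1, 2 and 3. Nothing available gives a reason for these differences.

Since 3-bromophenyl and 4-methoxyphenyl differ both in the attached group and in the number in their names, these compounds cannot show whether the higher number goes with the bromine or with its placement on the ring; 4-bromophenyl and 3-methoxyphenyl would separate the two. Also open, going by these compounds, is how this position responds to groups of other kinds, such as an amine, a carboxylic acid or a longer chain in place of the aromatic ring.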